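A few compounds are considered here, and "the series" means these few. Any claim that something is new, unique, unknown or untested is made for them only; others in the source may bear on it.

Of the compounds shown here, three sharing one core have so far been measured in a functional assay on MDA-MB-435 cells (Homo sapiens) for inhibition, read by sulforhodamine B assay, with a stated time of 48 h; on this read-out higher numbers stand for weaker inhibition of growth and lower numbers for stronger inhibition of growth. Compound 1 `COc1ccc(-c2cc(/C=C/C(=O)c3ccc(OC)c(OC)c3)[nH]n2)cc1` gives 1840 nM, compound 3 `COc1ccc(-c2cc(/C=C/C(=O)c3ccc(N)cc3)[nH]n2)cc1OC` gives 2530 nM, and compound 2 `COc1cc(-c2cc(/C=C/C(=O)c3ccc(Cl)c(Cl)c3)[nH]n2)cc(OC)c1OC` gives 5650 nM, the highest of the three numbers; its gaps to compound 3 and to compound 1 both lie beyond the usual scatter. Compound 4 `COc1ccc(C(=O)/C=C/c2cc(-c3cc(OC)c(OC)c(OC)c3)n[nH]2)cc1OC` has not yet been measured. It differs from compound 2 in one place: 3,4-dimethoxyphenyl in place of 3,4-dichlorophenyl on a carbonyl carbon. Within the data shown here, no measured pair shows this change on its own. Compound 1 does carry a 3,4-dimethoxyphenyl on its carbonyl carbon and gives 1840 nM, a lower number than compound 2. On that basis a modest lowering of the number is expected, a 2.6-fold lower number from compound 2 to compound 4 (0.41 log units; beyond the scatter), near the edge of the scatter. The estimate for compound 4 is 2200 nM, in a range from 900 nM to 5500 nM.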

Compound 4, concentration for 50% growth inhibition: 1340 nM
Beside the measured number, compound 4's estimate is 1.6-fold (0.22 log units) above it; the range from low to high includes it.
By their numbers in this assay, from the lowest: compounds 4, 1 and 3 (each within the scatter of the next); then compound 2.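

In this assay, 3,4-dimethoxyphenyl in place of 3,4-dichlorophenyl on a carbonyl carbon gives a 4.2-fold lower number from compound 2 to compound 4 (0.62 log units; beyond the scatter) with nothing else in the molecule altered. Among these compounds, this is the first reading of this change on its own, and it shows that the group at this place can move the number beyond the scatter. Nothing available here explains the size or direction of this step.

Still open, from the compounds shown here alone, is how a 3,4-difluorophenyl or a 3,4-diethoxyphenyl would read at this place. Going by these compounds, whether the same swap gives a similar step with a different group on the other side of the shared core also remains open.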